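Removing the trifluoromethyl group: expectation for compound 3

A few compounds are considered here, and "the series" means these few. Any claim that something is new, unique, unknown or untested is made for them only; others in the source may bear on it.

Measured compounds, in an assay on isolated protein for inhibition of Nicotinamide phosphoribosyltransferase (Homo sapiens), read by mass spectrometry, with stated times of 15 min and 30 min; a lower number here means a stronger inhibitor, a higher number a weaker inhibitor:
Compound 1 `COc1cccc(S(=O)(=O)c2ccc(CN/C(=N\C#N)Nc3ccncc3)cc2)c1` gives 1.9 nM.
Compound 2 `N#C/N=C(\NCc1ccc(S(=O)(=O)c2cccc(C(F)(F)F)c2)cc1)Nc1ccncc1` gives 2.4 nM.

For the measured compounds named here, compound 2 carries the higher of the two numbers in this assay, but the only step available, a 1.3-fold higher number from compound 1 to compound 2 (0.10 log units; within the scatter), lies within the scatter, so compound 2 and compound 1 cannot be separated on these data. That step swaps one group for another on the same aromatic carbon; both partners keep a substituent there.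

Compound 3 `N#C/N=C(\NCc1ccc(S(=O)(=O)c2ccccc2)cc1)Nc1ccncc1` takes that position one step further: hydrogen in place of trifluoromethyl on an aromatic carbon. Going by the values given here, no measured pair covers loss of the substituent altogether, so the only guide is the methoxy-to-trifluoromethyl exchange, which moved nothing beyond the scatter. Among the compounds with values here, on that basis the substituent at this place appears to matter little, and the step of a 1.5-fold higher number from compound 2 to compound 3 (0.16 log units; within the scatter) is expected to be small, with a slight lean toward a higher number since the unsubstituted case has no precedent here. Compound 3 is therefore estimated at 3.5 nM, within a range of 1.2 nM to 10 nM.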

Compound 3, half-maximal inhibitory concentration: 2.5 nM
The estimate for compound 3 lay 1.4-fold (0.15 log units) above the measured number, within the range that was stated.
By their numbers in this assay, from the lowest: compounds 1, 2 and 3 (each within the scatter of the next).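

In this assay, hydrogen in place of trifluoromethyl gives a 1.0-fold higher number from compound 2 to compound 3 (0.02 log units; within the scatter), and hydrogen in place of methoxy gives a 1.3-fold higher number from compound 1 to compound 3 (0.12 log units; within the scatter). The earlier pair compared only two substituents on this aromatic carbon, whereas the series now includes the unsubstituted phenyl, and compounds 1, 2 and 3 cannot be separated, so across these three compounds the presence of a substituent here makes no readable difference to the number. No supporting data accompany these values to account for this result.

As far as these compounds go, whether an amine, a carboxylic acid or a longer chain such as butoxy on this aromatic carbon would also stay within the scatter remains open, since methoxy and trifluoromethyl are the only two substituents that can be compared with hydrogen here. The three compounds also speak only to this one carbon and to this assay, so substitution elsewhere on the ring and the behaviour of the series in cells remain unresolved.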